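Methylsulfonyl to dimethylcarbamoyl on the para aryl position

The source may hold more compounds than are shown below. What is called first, only, known or untested is meant among the compounds shown, and "the series" means these compounds.

Two measured compounds frame this step. Compound 1 `CC(C)(C)OC(=O)N1CCC(CCCOc2ccc(S(C)(=O)=O)cc2)CC1` carries the shorter chain between the piperidine and the aryl ether; in a functional assay on HEK293 cells for agonist activity at Glucose-dependent insulinotropic receptor (Homo sapiens), read by cAMP accumulation, with a stated time of 30 min (on this read-out higher numbers stand for an effect only at larger amounts of compound and lower numbers for an effect already at smaller amounts), compound 1 gives 353 nM. Compound 2 `CC(C)(C)OC(=O)N1CCC(CCCCCOc2ccc(S(C)(=O)=O)cc2)CC1` differs by the longer chain, and in this assay compound 2 gives 14 nM, the lowest of the two numbers and beyond the scatter from compound 1.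

Compound 3 `CN(C)C(=O)c1ccc(OCCCCCC2CCN(C(=O)OC(C)(C)C)CC2)cc1` keeps the longer chain and the rest of compound 2 and differs only at the aryl terminus: dimethylcarbamoyl in place of methylsulfonyl on an aromatic carbon. Among the measured compounds shown here, no measured pair in the set isolates this change, so its size can only be guessed. For the measured compounds named here, a moderate step toward a higher number is expected, a 2.9-fold higher number from compound 2 to compound 3 (0.46 log units; beyond the scatter), on the grounds that compound 2 at 14 nM already sits at the low end of the series and a change at the terminus has no precedent here in either direction.

In this assay compound 3 is estimated at 40 nM, with a plausible range from 10 nM to 160 nM.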

Compound 3, half-maximal effective concentration in the Glucose-dependent insulinotropic receptor assay: 5 nM
The estimate for compound 3 lay 8.0-fold (0.90 log units) above the measured number; measured number outside the range, below it.
By their numbers in the Glucose-dependent insulinotropic receptor assay, from the lowest: compound 3; then compound 2; then compound 1.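

At this aromatic carbon, dimethylcarbamoyl in place of methylsulfonyl gives a lower number in the Glucose-dependent insulinotropic receptor assay, a 2.8-fold lower number from compound 2 to compound 3 (0.45 log units; beyond the scatter), so methylsulfonyl is not required for activity in this compound pair. The earlier compounds shown here varied only the chain, and this step adds the aryl terminus as a second place where the read-out changes, here with the longer chain held constant. The lower number in the Glucose-dependent insulinotropic receptor assay also comes without a loss of solubility in a physicochemical assay for solubility, in simulated intestinal fluid (on this read-out higher numbers stand for higher solubility and lower numbers for lower solubility), as the change goes with higher solubility: the measured solubility of compound 2, 15900 nM, and of compound 3, 74200 nM, a 4.7-fold higher number (0.67 log units; beyond the scatter) In the physicochemical assay compound 2 gives 15900 nM and compound 3 gives 74200 nM.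

Going by these compounds, the step rests on one matched pair, so it remains open whether dimethylcarbamoyl gives a lower number with the shorter chain of compound 1, and whether the solubility change carries over to that chain as well. Also open, on these data alone, is how other groups on this aromatic carbon, such as a nitrile, a primary carboxamide, a carboxylic acid or a cyclic amide like pyrrolidine-1-carbonyl, would compare with dimethylcarbamoyl on both read-outs.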